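From 4-chlorophenyl to 4-nitrophenyl

The source may report more compounds than this note shows. Statements on the series, on what has been measured and on what is new or still open speak of the compounds shown alone.

In a functional assay on A549 cells (Homo sapiens) for antiproliferative activity, read by MTT assay, with a stated time of 72 h (on this read-out lower numbers stand for stronger inhibition and higher numbers for weaker inhibition), compound 1 `Nc1ccccc1NC(=O)CCCCCCc1nc(-c2ccccc2)no1` gives 23900 nM and compound 3 `Nc1ccccc1NC(=O)CCCCCCc1nc(-c2ccc(Cl)cc2)no1` gives 13800 nM, two values within the scatter of each other. Compound 2 `Nc1ccccc1NC(=O)CCCCCCc1nc(-c2ccc(C(F)(F)F)cc2)no1` reads > 100000 nM, which is a limit of the assay. Compound 4 `Nc1ccccc1NC(=O)CCCCCCc1nc(-c2ccc([N+](=O)[O-])cc2)no1` carries nitro in place of chloro on an aromatic carbon. Among the compounds with values here, three measured steps bear on this place: a 1.7-fold lower number from compound 1 to compound 3 (0.24 log units; within the scatter) stays within the scatter, while an at least 4.1-fold higher number from compound 1 to compound 2 (0.62 log units; beyond the scatter) and an at least 7.2-fold lower number from compound 2 to compound 3 (0.86 log units; beyond the scatter) go beyond it. Within the data shown here, a moderately higher number is expected for nitro, the only guide to a rise being the result of compound 2, > 100000 nM. The expected change is a 2.2-fold higher number from compound 3 to compound 4 (0.34 log units; beyond the scatter). The estimate for compound 4 is 30000 nM, with an expected range of 9000 nM to 100000 nM.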

Compound 4, half-maximal inhibitory concentration: > 100000 nM
Compound 4 gave a limit, no number (the forecaster's own chance of this, stated with the estimate: 20%); at least 3.3-fold (0.52 log units) between middle value and limit.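

In this assay, nitro in place of chloro gives an at least 7.2-fold higher number from compound 3 to compound 4 (0.86 log units; beyond the scatter), and nitro in place of hydrogen gives an at least 4.1-fold higher number from compound 1 to compound 4 (0.62 log units; beyond the scatter). Trifluoromethyl is thus no longer the only group at this place to end at a limit, while chloro stays within the scatter of hydrogen. The step between compound 2 and compound 4 cannot be read, as both values are limits: the limit of > 100000 nM in this assay, at which 2 of the 4 values shown sit.

As far as these compounds go, whether an amine or a methoxy group at this place would stay with compound 1 and compound 3 or also reach the limit remains open.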